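Removing the methoxy groups from the thioether aryl of compound 2

This account rests on a few compounds, and the source may have more. Where it says the series, first, only, none or still open, it means among the compounds named here.

Three measured compounds share a core carrying a benzylthio group and a five-membered heteroaryl. Compound 1 `COc1cc(CSc2cc(Cl)c(-c3nnc(-c4ccc(Cl)cc4)s3)cc2S(=O)(=O)NC(=N)NO)cc(OC)c1OC` gives 34700 nM in a functional assay on NCI-H460 cells (Homo sapiens); a higher number here means a weaker inhibitor of growth, a lower number a stronger inhibitor of growth. Compound 2 `COc1cc(CSc2cc(Cl)c(-c3nc(-c4ccccc4)no3)cc2S(=O)(=O)NC(=N)NO)cc(OC)c1OC` gives 4370 nM in this assay, and compound 3 `COc1cc(CSc2cc(Cl)c(-c3nnc(-c4ccccc4)s3)cc2S(=O)(=O)NC(=N)NO)cc(OC)c1OC` gives 3240 nM. Compound 2 stands well apart from compound 1, with a 7.9-fold lower number from compound 1 to compound 2 (0.90 log units; beyond the scatter), while the step of a 1.3-fold lower number from compound 2 to compound 3 (0.13 log units; within the scatter) leaves compound 2 and compound 3 indistinguishable within the scatter. The other measured step, an 11-fold lower number from compound 1 to compound 3 (1.03 log units; beyond the scatter), is also a change on the heteroaryl side.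

Compound 4 `N=C(NO)NS(=O)(=O)c1cc(-c2nc(-c3ccccc3)no2)c(Cl)cc1SCc1ccccc1` has not been measured. It differs from compound 2 by phenyl in place of 3,4,5-trimethoxyphenyl on a saturated chain carbon bound to a sulfur. None of the three measured steps touches this part of the molecule; all of them alter the heteroaryl or its chloro substituent, so the data give no direct guidance on this change. In that absence, the expectation for compound 4 in this assay is a number near that of compound 2, with a step of a 1.1-fold higher number from compound 2 to compound 4 (0.06 log units; within the scatter) that is not expected to go beyond the scatter in either direction, and a wide range to reflect the lack of a matching measured step. The estimate for compound 4 in this assay is therefore 5000 nM, with a range from 1500 nM to 20000 nM.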

Compound 4, concentration for 50% growth inhibition: 1940 nM
Compound 4: the middle estimate sits 2.6-fold (0.41 log units) above what was measured; low and high end bracket the measured number.
By their numbers in this assay, from the lowest: compounds 4, 3 and 2 (each within the scatter of the next, the first and the last beyond it); then compound 1.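

In this assay, within the data shown here, the step of a 2.3-fold lower number from compound 2 to compound 4 (0.35 log units; beyond the scatter) is the first reading at this end of the molecule, since all the earlier steps lay on the heteroaryl side. It shows that the 3,4,5-trimethoxyphenyl on a saturated chain carbon bound to a sulfur is not required for growth inhibition in this series: plain phenyl, with no methoxy groups, keeps the activity and gives a modest improvement that lies beyond the scatter. No supporting measurement accounts for this improvement, so the result records the effect of the change without explaining it.

The compounds shown leave open whether all the methoxy groups must go, as a phenyl bearing a single methoxy group has no reading here, and whether other replacements such as 4-fluorophenyl, cyclohexyl or a plain methyl on the sulfur would follow phenyl or depart from it. They also leave open whether the same exchange would carry over to compound 3, whose 5-phenyl-1,3,4-thiadiazol-2-yl group differs from the heteroaryl of compound 2 and compound 4.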